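Methoxy on the phenyl of compound 1

The compounds below may be only part of what the source reports. "The series", "measured", "known", "first", "only" and "open" are said of these compounds alone.

Compound 1 `c1ccc(-c2cn3ccnc3c(-c3ccc4ncn(C5CCCCC5)c4c3)n2)cc1` carries a plain phenyl on a shared core. In a functional assay on KM12 cells (Homo sapiens) for inhibition, read by sulforhodamine B assay, with a stated time of 48 h, tested at 10 uM (a higher number here means more inhibition at the concentration tested (going by the name of the read-out), a lower number less inhibition), compound 1 gives 49%, the highest of the three measured numbers. Two measured relatives change that phenyl. Compound 2 `O=Cc1ccc(-c2cn3ccnc3c(-c3ccc4ncn(C5CCCCC5)c4c3)n2)cc1` gives 3.69% in this assay, and compound 3 `CC(=O)c1ccc(-c2cn3ccnc3c(-c3ccc4ncn(C5CCCCC5)c4c3)n2)cc1` gives 11.7%. Both steps from compound 1 are large losses: a number 45.3 percentage points lower from compound 1 to compound 2 (beyond the scatter) with a formyl in place of hydrogen on an aromatic carbon, and a number 37.3 percentage points lower from compound 1 to compound 3 (beyond the scatter) with an acetyl in place of hydrogen on an aromatic carbon. Between the two carbonyl compounds the change is small, a number 8 percentage points higher from compound 2 to compound 3 (within the scatter).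

Compound 4 `COc1ccccc1-c1cn2ccnc2c(-c2ccc3ncn(C4CCCCC4)c3c2)n1` has not yet been measured. Its difference from compound 1 is methoxy in place of hydrogen on an aromatic carbon. Among the compounds with values here, no measured step adds a methoxy, so the formyl and acetyl steps bear on it only loosely: they show that adding a group to this phenyl can cost a great deal, but a methoxy carries no carbonyl, and its place is ortho to a large group rather than the place the carbonyl groups took. A drop beyond the scatter is therefore expected, but a smaller one than either measured step; the expected step is a number 17 percentage points lower from compound 1 to compound 4 (beyond the scatter). Compound 4 is estimated to give 32%, within a range from 8% to 58%.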

Compound 4, a percentage reported as inhibition, at one concentration (the size of the read-out at that concentration, not a potency): 3.58%
The estimate for compound 4 lay 28.4 percentage points above the measured number; the measured number lies below the stated range.
By their numbers in this assay, from the lowest: compounds 4, 2 and 3 (each within the scatter of the next); then compound 1.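

A methoxy carries no carbonyl, yet in this assay it costs as much as the formyl and acetyl groups did (a number 45.4 percentage points lower from compound 1 to compound 4 (beyond the scatter)), so the loss on this phenyl is not tied to a carbonyl and also appears with a group ortho to a large group. The three substituted compounds sit within the scatter of one another (a number 8.1 percentage points lower from compound 3 to compound 4 (within the scatter); a number 0.1 percentage points lower from compound 2 to compound 4 (within the scatter)), which means this assay does not separate 2-methoxyphenyl from 4-acetylphenyl or 4-formylphenyl. Among these four compounds, only the plain phenyl of compound 1 stands clear of the rest, and nothing shown here offers an explanation for the drop.

Because the methoxy differs from the carbonyl groups in both its identity and its place on the ring, the compounds leave open whether the place or the group matters more, and a methoxy at the place held by the acetyl of compound 3 would help separate the two. Going by these compounds, it also remains open whether a single fluorine atom, an amine or a carboxylic acid on this phenyl would keep the number of compound 1 or lose it as well.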